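The source may report more compounds than this note shows. Statements on the series, on what has been measured and on what is new or still open speak of the compounds shown alone.

Measured so far in a functional assay on NCI-H460 cells (Homo sapiens) for cytotoxicity, read by MTT assay; a lower number here means a stronger inhibitor, a higher number a weaker inhibitor:
- compound 1, `CCCOC(=O)Nc1ccc(S(=O)(=O)N2C[C@H](c3ccccc3)NC2=O)cc1CC`: 60 nM
- compound 2, `CCc1cc(S(=O)(=O)N2C[C@H](c3ccccc3)NC2=O)ccc1NC(=O)OC(C)C`: 60 nM
- compound 3, `CCOC(=O)Nc1ccc(S(=O)(=O)N2C[C@H](c3ccccc3)NC2=O)cc1Cl`: 20 nM

Compound 3 holds the lowest number of the three; compound 1 and compound 2 each sit at a gap from it that is beyond the scatter. Among the compounds with values here, the one measured step, no change at the digits printed from compound 1 to compound 2 (within the scatter), shows that swapping isopropyl for propyl on an oxygen next to a carbonyl group leaves this assay unchanged.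

The next compound, compound 4, `CCOC(=O)Nc1ccc(S(=O)(=O)N2C[C@H](c3ccccc3)NC2=O)cc1CC`, differs from compound 3 as follows: ethyl in place of chloro on an aromatic carbon. Within the data shown here, no measured step covers a chloro-to-ethyl swap directly, so the step from compound 1 to compound 2 bears on it only in showing that the other variable part of the series is tolerant. Compound 1 and compound 2, which carry the ethyl group that enters here, both give the higher number, and compound 3 with chloro gives the lower one; on these two values alone an upward step toward those numbers is expected in this assay. The estimated step is a 2.5-fold higher number from compound 3 to compound 4 (0.40 log units; beyond the scatter). Compound 4 is therefore expected to come in near 50 nM, with a range of 20 nM to 120 nM.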

Compound 4, half-maximal inhibitory concentration: 70 nM
Estimate against measurement, compound 4: 1.4-fold (0.15 log units) below, and the stated range covers the measured number.
By their numbers in this assay, from the lowest: compound 3; then compounds 1, 2 and 4 (each within the scatter of the next).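

In this assay, the aromatic carbon ortho to the (ethoxycarbonyl)amino group now has a direct one-place comparison: ethyl in place of chloro gives a 3.5-fold higher number from compound 3 to compound 4 (0.54 log units; beyond the scatter), a modest step beyond the scatter, so this position responds to the change. With ethyl on the ring, the chain on the oxygen next to a carbonyl group does not separate the compounds: hydrogen in place of methyl gives a 1.2-fold higher number from compound 2 to compound 4 (0.07 log units; within the scatter) and also a 1.2-fold higher number from compound 1 to compound 4 (0.07 log units; within the scatter), both within the scatter. No supporting measurement bears on the reason for the chloro-to-ethyl step.

Going by these compounds, whether chloro keeps its lower number with propyl or isopropyl on that oxygen remains open. Also open, on these data alone, is how fluoro, bromo, methoxy or a nitrile would compare at the same aromatic carbon.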